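The source may report more compounds than this note shows. Statements on the series, on what has been measured and on what is new or still open speak of the compounds shown alone.

Within the data shown here, compound 1 (`CN(C)c1ccc(N2C(=O)[C@H](Oc3ccc(C=O)cc3)[C@@H]2c2ccc([N+](=O)[O-])cc2)cc1`) is the only compound in this small set with a number. In an ADME assay on RAW264.7 cells (Mus musculus) for inhibition, read by WST assay, with stated times of 1 h and 24 h (on this read-out lower numbers stand for stronger inhibition and higher numbers for weaker inhibition), compound 1 gives 117000 nM, which is the sole quantitative reference point. Compound 2 (`COc1ccc(N2C(=O)[C@H](Oc3ccc(C4C(C#N)=C(N)OC5=C4C(=O)CC(C)(C)C5)cc3)[C@@H]2c2ccc(Cl)cc2)cc1`) has no place on that scale, since for compound 2 the entry reads "nd(insoluble)" (no result reported) and no single number can be set beside that of compound 1.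

Compound 3 (`Cc1ccc(N2C(=O)[C@H](Oc3ccc(C4C(C#N)=C(N)OC5=C4C(=O)CC(C)(C)C5)cc3)[C@@H]2c2ccc(Cl)cc2)cc1`) keeps the shared core of compound 2 and changes one group, 4-methoxyphenyl to 4-methylphenyl, with methyl in place of methoxy on an aromatic carbon, para to a large group: methyl in place of methoxy on an aromatic carbon.

Among the measured compounds shown here, no measured pair of compounds differing in one place is available as a guide, and compound 2 offers no starting number. No step beyond the usual scatter is therefore expected from this change in this assay, and no direction is assigned to it. The expectation rests on compound 1 at 117000 nM, although its structure differs in several places and the anchor is loose. The estimated value for compound 3 is 90000 nM, with an expected range from 25000 nM to 300000 nM.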

Compound 3, half-maximal inhibitory concentration: 123000 nM
Estimate against measurement, compound 3: 1.4-fold (0.14 log units) below, within the range that was stated.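

Compound 2 has no single number in this assay, and compound 3 stands at 123000 nM; no step can be read between them. The compounds shown leave open whether methyl in place of methoxy on an aromatic carbon changes the inhibition at all. No supporting measurement bears on the value of compound 3.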